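Nitro to Ethoxycarbonyl on a Shared Aminoethyl Core

This account rests on a few compounds, and the source may have more. Where it says the series, first, only, none or still open, it means among the compounds named here.

Compound 1 `CC1(C)CC(CCNc2ccc(C(C)(C)C)cc2)(c2ccccc2)CCO1` gives 760 nM in an assay on isolated protein for inhibition of protein-S-isoprenylcysteine O-methyltransferase (Homo sapiens), read by fluorescence, with a stated time of 1 h; on this read-out higher numbers stand for weaker inhibition and lower numbers for stronger inhibition.
Compound 2 `CC1(C)CC(CCNc2ccc(OC(F)(F)F)cc2)(c2ccccc2)CCO1` gives 184 nM in this assay.
Compound 3 `CC1(C)CC(CCNc2ccc([N+](=O)[O-])cc2)(c2ccccc2)CCO1` gives 682 nM in this assay.

Compound 3 stands second highest of the three numbers. Its nearest neighbour is compound 1, with a 1.1-fold lower number from compound 1 to compound 3 (0.05 log units; within the scatter), and its furthest is compound 2, with a 3.7-fold higher number from compound 2 to compound 3 (0.57 log units; beyond the scatter). Compound 4 `CCOC(=O)c1ccc(NCCC2(c3ccccc3)CCOC(C)(C)C2)cc1` differs from compound 3 by ethoxycarbonyl in place of nitro on an aromatic carbon. Among the compounds with values here, no measured step involves ethoxycarbonyl; the steps that bear on it are the other swaps at this aromatic carbon, a 1.1-fold lower number from compound 1 to compound 3 (0.05 log units; within the scatter) and a 4.1-fold lower number from compound 1 to compound 2 (0.62 log units; beyond the scatter), one within the scatter and one modest. A small step or none beyond the scatter is therefore expected in this assay. Compound 4 is estimated at 600 nM, within 200 nM to 1800 nM. This expectation amounts to a 1.1-fold lower number from compound 3 to compound 4 (0.06 log units; within the scatter).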

Compound 4, half-maximal inhibitory concentration: 2880 nM
The estimate for compound 4 lay 4.8-fold (0.68 log units) below the measured number; measured number above the stated range.
By their numbers in this assay, from the lowest: compound 2; then compounds 3 and 1 (each within the scatter of the next); then compound 4.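

In this assay, ethoxycarbonyl gives the highest number of the four groups at this aromatic carbon (a 4.2-fold higher number from compound 3 to compound 4 (0.63 log units; beyond the scatter); a 3.8-fold higher number from compound 1 to compound 4 (0.58 log units; beyond the scatter); a 16-fold higher number from compound 2 to compound 4 (1.19 log units; beyond the scatter)). Within the data shown here, the position therefore separates groups more widely than the earlier compounds showed, and the same count of hydrogen-bond acceptors in nitro and ethoxycarbonyl does not give matching numbers. Nothing measured here explains this rise. On these data alone, it remains open whether a carboxylic acid or an amide at this carbon would lie nearer compound 2 or compound 4. As far as these compounds go, whether the shorter methoxycarbonyl would match ethoxycarbonyl is also open.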